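Compound 3: ring size on the sulfonamide nitrogen

A few compounds are considered here, and "the series" means these few. Any claim that something is new, unique, unknown or untested is made for them only; others in the source may bear on it.

Within the data shown here, in a physicochemical assay for solubility, with a stated time of 24 h, tested at 30 mg/mL (a lower number here means a less soluble compound, a higher number a more soluble compound), compound 1 `Cc1cc(COc2ccc(S(=O)(=O)NCC(=O)NO)cc2)c2ccccc2n1` gives 100000 nM and compound 2 `Cc1cc(COc2ccc(S(=O)(=O)NC3(C(=O)NO)CCCC3)cc2)c2ccccc2n1` gives 200000 nM, so compound 2 stands within the scatter of the only other measured compound. Compound 3 `Cc1cc(COc2ccc(S(=O)(=O)NC3(C(=O)NO)CCCCC3)cc2)c2ccccc2n1` differs from compound 2 by a group of 10 heavy atoms (7 carbon, 1 nitrogen, 2 oxygen; one six-membered non-aromatic ring of carbon only) in place of a group of 9 heavy atoms (6 carbon, 1 nitrogen, 2 oxygen; one five-membered non-aromatic ring of carbon only), on a sulfonamide nitrogen. Among the measured compounds shown here, the one measured step bearing on this change, at the same sulfonamide nitrogen, is a 2.0-fold higher number from compound 1 to compound 2 (0.30 log units; within the scatter). With a larger replacement there leaving this assay within the scatter, the expected result is a 1.3-fold lower number from compound 2 to compound 3 (0.12 log units; within the scatter), with no shift beyond the scatter. Compound 3 is estimated at 150000 nM, with an expected range of 50000 nM to 400000 nM.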

Compound 3, solubility: 11000000 nM
For compound 3 the middle estimate is 73-fold (1.87 log units) below the measured one; measured number above the stated range.
By their numbers in this assay, from the lowest: compounds 1 and 2 (each within the scatter of the next); then compound 3.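

In this assay, the six-membered non-aromatic ring of carbon only in place of the five-membered one, on a sulfonamide nitrogen, gives a large step (a 55-fold higher number from compound 2 to compound 3 (1.74 log units; beyond the scatter)). Against the group without a ring, the same six-membered ring also gives a large step (a 110-fold higher number from compound 1 to compound 3 (2.04 log units; beyond the scatter)), so this position responds to ring size in a way the earlier pair, within the scatter, did not show. Nothing on hand accounts for this jump. From the compounds shown here alone, whether a seven-membered ring of carbon only would extend or lose the gain stays open. So does the effect of an amine on the six-membered ring.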